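Stereo-defined analogue of the 4-hydroxyphenyl hydrazone

The source may hold more compounds than are shown below. What is called first, only, known or untested is meant among the compounds shown, and "the series" means these compounds.

Three hydrazones on the shared core have been measured in a functional assay on the whole organism for inhibition, with Rattus norvegicus as the target; a higher number here means that more compound is needed for the effect, a lower number that less compound is needed. Compound 1 `CC1CC/C(=N\Nc2cccc(Br)c2)c2ncc(C(=O)O)c(=O)n21` gives 0.4 umol/kg. Compound 2 `CC1CC/C(=N\Nc2ccccc2O)c2ncc(C(=O)O)c(=O)n21` gives 0.26 umol/kg; the step of a 1.5-fold lower number from compound 1 to compound 2 (0.19 log units; within the scatter). Compound 3 `CC1CC/C(=N\Nc2ccc(O)cc2)c2ncc(C(=O)O)c(=O)n21` gives 1.7 umol/kg; the step of a 4.3-fold higher number from compound 1 to compound 3 (0.63 log units; beyond the scatter), and the step of a 6.5-fold higher number from compound 2 to compound 3 (0.82 log units; beyond the scatter). Compound 3 thus stands highest of the three numbers, beyond the scatter from both others, with compound 1 nearest.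

Compound 4 `C[C@H]1CC/C(=N\Nc2ccc(O)cc2)c2ncc(C(=O)O)c(=O)n21` is the next analogue. Relative to compound 3 the change is: the two compounds have the same atoms and bonds; at least one stereo element is drawn with a configuration in one of them and without one in the other: 1 of 2 stereo elements differ; a stereocentre at a saturated ring carbon is drawn without a configuration in compound 3 and S in compound 4. Within the data shown here, none of the three measured steps bears on this: each of them swaps the aryl group on the amine nitrogen and leaves every stereo element as drawn, so there is no measured step that speaks to a single configuration versus an undefined one. Compound 4 carries the same 4-hydroxyphenyl as compound 3, and the expected step in this assay is none beyond the scatter, with the possibility that a defined configuration gives a somewhat lower number. For compound 4 the estimated value is 1.2 umol/kg, with a range from 0.4 umol/kg to 4 umol/kg. The expected step is therefore a 1.4-fold lower number from compound 3 to compound 4 (0.15 log units; within the scatter).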

Compound 4, dose for 50% inhibition: 111 umol/kg
Beside the measured number, compound 4's estimate is 93-fold (1.97 log units) below it, and the stated range ends below it.
By their numbers in this assay, from the lowest: compounds 2 and 1 (each within the scatter of the next); then compound 3; then compound 4.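

Setting the stereocentre at the saturated ring carbon as S, with atoms and bonds unchanged, gives a 65-fold higher number from compound 3 to compound 4 (1.81 log units; beyond the scatter) in this assay. The earlier steps shown here all swapped the aryl group on the amine nitrogen, and none of them reached this size, so this carbon is a far more sensitive point than those aryl changes suggested. The only structural difference that goes with the step is this: the fact that one of compounds 3 and 4 is drawn with a defined configuration and the other without, at the place where they differ

Open, from the compounds shown here alone, is where the R configuration at this carbon would stand relative to compound 3 and compound 4, and whether S has a similar effect with 2-hydroxyphenyl or 3-bromophenyl on the amine nitrogen. Also open, going by these compounds, is how a methyl ester in place of the carboxylic acid would behave with either configuration.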